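The compounds below may be only part of what the source reports. "The series", "measured", "known", "first", "only" and "open" are said of these compounds alone.

Measured compounds:
- Compound 1, `COc1ccc(-n2c(C)nc3c(NC(C4CC4)C4CC4)nc(C)nc32)cc1`: 19 nM
- Compound 2, `COc1ccc(-n2c(C)nc3c(NC(C4CC4)C4CC4)nc(C)nc32)c(C)c1`: 14 nM
- Compound 3, `Cc1nc(NC(C2CC2)C2CC2)c2nc(C)n(-c3ccc(C#N)cc3)c2n1`: 62 nM

The three compounds share a core and differ only in the aryl group on the aromatic nitrogen. In a functional assay on CHO cells for antagonist activity at corticotropin-releasing factor receptor 1 (Homo sapiens), read by cAMP accumulation (on this read-out lower numbers stand for stronger inhibition and higher numbers for weaker inhibition), compound 3 gives the highest number of the three: a 3.3-fold higher number from compound 1 to compound 3 (0.51 log units; beyond the scatter) and a 4.4-fold higher number from compound 2 to compound 3 (0.65 log units; beyond the scatter) place it beyond the scatter from both of the others, whereas a 1.4-fold lower number from compound 1 to compound 2 (0.13 log units; within the scatter) stays within it. Compound 4, `Cc1nc(NC(C2CC2)C2CC2)c2nc(C)n(-c3ccc(S(C)(=O)=O)cc3)c2n1`, has not yet been measured. It differs from compound 3 by one change: methylsulfonyl in place of cyano on an aromatic carbon. Among the compounds with values here, no measured step replaces a cyano group or introduces a methylsulfonyl group; the steps that touch this position only exchange methoxy for cyano, as in a 3.3-fold higher number from compound 1 to compound 3 (0.51 log units; beyond the scatter), or exchange the whole aryl group, as in a 4.4-fold higher number from compound 2 to compound 3 (0.65 log units; beyond the scatter). Both of those steps were modest and both moved the number up when cyano entered. On that basis compound 4 is expected to land near compound 3 or somewhat higher in this assay, as an estimate 80 nM with a range from 25 nM to 250 nM, and the expected step of a 1.3-fold higher number from compound 3 to compound 4 (0.11 log units; within the scatter) is not likely to exceed the scatter by much.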

Compound 4, inhibition constant: 140 nM
Compound 4: middle estimate off by 1.8-fold (0.24 log units), on the low side; the measured number falls inside the stated range.
By their numbers in this assay, from the lowest: compounds 2 and 1 (each within the scatter of the next); then compound 3; then compound 4.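

In this assay, this aromatic carbon, para to a large group, proves sensitive to a change between two groups that both differ from methoxy: methylsulfonyl in place of cyano gives a 2.3-fold higher number from compound 3 to compound 4 (0.35 log units; beyond the scatter), a step beyond the scatter. Measured against the methoxy group, methylsulfonyl gives a 7.4-fold higher number from compound 1 to compound 4 (0.87 log units; beyond the scatter), the largest step among these compounds, so both replacements of methoxy shown here raise the number, and methylsulfonyl raises it further than cyano. Nothing available explains why these groups differ in this way.

The compounds shown leave open whether a simple amine, a chlorine atom or a longer alkoxy chain on this carbon would keep the number near that of methoxy. They also leave open how methylsulfonyl behaves when the aryl group carries the extra methyl found in compound 2.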